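A ring swap at the assay limit

The source may hold more compounds than are shown below. What is called first, only, known or untested is meant among the compounds shown, and "the series" means these compounds.

Values in a functional assay on SK-OV-3 cells (Homo sapiens) for antiproliferative activity, read by MTT assay, with a stated time of 24 h; a lower number here means a stronger inhibitor, a higher number a weaker inhibitor:
- Compound 1 `COc1ccc(C(=O)/C=C/c2cccc([N+](=O)[O-])c2)c2c1C=CC(C)(C)O2`: 9720 nM
- Compound 2 `COc1ccc(C(=O)/C=C/c2ccccc2)c2c1C=CC(C)(C)O2`: > 10000 nM, a limit
- Compound 3 `COc1ccc(/C=C/C(=O)c2ccc(OC)c3c2OC(C)(C)C=C3)cn1`: > 10000 nM, a limit

Compound 3 gives no exact number, only the limit > 10000 nM. Compound 2 sits at the same limit, so the series is dominated by the limit of > 10000 nM in this assay, at which 2 of the 3 values shown sit. Only compound 1 gives a true number, 9720 nM.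

Compound 4 `COc1ccc(C(=O)/C=C/c2ccco2)c2c1C=CC(C)(C)O2` keeps the shared core and changes one group, on a double-bonded chain carbon bound to a double-bonded chain carbon: furan-2-yl in place of 6-methoxypyridin-3-yl on a double-bonded chain carbon bound to a double-bonded chain carbon.

Two measured changes at this same place bear on it. The first is an at least 1.0-fold higher number from compound 1 to compound 3 (0.01 log units; that floor lies within the scatter). The second is a step that the two limits leave unreadable from compound 2 to compound 3. Within the data shown here, neither shows a step beyond the scatter, and the one other measured step, at a different place, is an at least 1.0-fold higher number from compound 1 to compound 2 (0.01 log units; that floor lies within the scatter). So no clear shift is expected in this assay, and a further limit is quite possible.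

The expected step is a step that the limit leaves unreadable from compound 3 to compound 4. Compound 4 is estimated at 12000 nM, with an expected range of 5000 nM to 30000 nM.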

Compound 4, half-maximal inhibitory concentration: > 10000 nM
Compound 4 gave a limit, no number; the forecaster's own chance of this, stated with the estimate: 60%; the middle value lies beyond the limit too.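

In this assay, furan-2-yl now joins phenyl and 6-methoxypyridin-3-yl on this double-bonded chain carbon, so a five-membered aromatic ring in place of a six-membered one also gives a limit rather than an exact number. Among these compounds, the steps from compound 2 and from compound 3 to compound 4 cannot be read, and the one readable step is an at least 1.0-fold higher number from compound 1 to compound 4 (0.01 log units; that floor lies within the scatter). The series now gathers even more tightly at a single point: the limit of > 10000 nM in this assay, at which 3 of the 4 values shown sit.

The compounds shown leave open whether a ring carrying an amine or a carboxylic acid, or a longer chain, at this place would give a step beyond the scatter. As far as these compounds go, how compound 2, compound 3 and compound 4 truly rank against one another also stays open.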